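Chain shortening on the ring nitrogen substituent

A few compounds are considered here, and "the series" means these few. Any claim that something is new, unique, unknown or untested is made for them only; others in the source may bear on it.

Two compounds of this series have numbers in an in vivo ADME assay on the whole organism for pharmacokinetics, with Cynomolgus monkey (Macaca fascicularis) as the target, at a dose of 1 mg/kg by the oral route; on this read-out higher numbers stand for higher oral bioavailability and lower numbers for lower oral bioavailability. Compound 1 `CC(C)(C)Cc1nn(CCC2CC2)c(=O)c(C2=NS(=O)(=O)c3cc(NS(C)(=O)=O)ccc3N2)c1O` gives 6% in this assay. Going by the values given here, compound 2 `CN(c1ccc2c(c1)S(=O)(=O)N=C(c1c(O)c(-c3cccs3)nn(CCC(C)(C)C)c1=O)N2)S(C)(=O)=O` gives 3% in this assay, and that number and the one of compound 1 lie within the scatter of each other, so the two stand on the same low level. Compound 3 `CC(C)CCn1nc(-c2cccs2)c(O)c(C2=NS(=O)(=O)c3cc(N(C)S(C)(=O)=O)ccc3N2)c1=O` is not yet measured in this assay. It differs from compound 2 in one place: hydrogen in place of methyl on a saturated chain carbon bound to three saturated chain carbons, a hydrogen in place of methyl on a saturated chain carbon bound to three saturated chain carbons. Among the compounds with values here, no step between measured compounds describes this change. Both measured compounds sit low, and the change is a single carbon, so the step from compound 2 to compound 3 in this assay is expected to be a number 1 percentage points higher from compound 2 to compound 3 (within the scatter), nothing beyond the scatter. Compound 3 is therefore expected to give 4% in this assay, with a range from 1% to 12%.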

Compound 3, oral bioavailability: 12%
Beside the measured number, compound 3's estimate is 8 percentage points below it; the range from low to high includes it.
By their numbers in this assay, from the lowest: compounds 2, 1 and 3 (each within the scatter of the next).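

Cutting the 3,3-dimethylbutyl chain to isopentyl, with hydrogen in place of methyl on a saturated chain carbon bound to three saturated chain carbons, gives the first readable one-place step in this assay: a number 9 percentage points higher from compound 2 to compound 3 (within the scatter). This single methyl can therefore go without a step beyond the scatter, and the full 3,3-dimethylbutyl branching is not needed to hold the read-out at this level. No data on hand account for the step, so it stands as an observation only.

On these data alone, with one pair and one change at this place, it remains open whether any replacement on this chain moves this assay beyond the scatter. An unbranched n-butyl chain, a longer chain, or a chain ending in an amine or a carboxylic acid would each test this.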